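A few compounds are considered here, and "the series" means these few. Any claim that something is new, unique, unknown or untested is made for them only; others in the source may bear on it.

Of the compounds shown here, two built on a shared core have been tested in a functional assay on HeLa cells (Homo sapiens) for cytotoxicity, read by CCK-8 assay; a higher number here means a weaker inhibitor, a lower number a stronger inhibitor. Compound 1 `Oc1ccc(-c2cc(-c3cccs3)cc(-c3ccccc3O)n2)cc1` yields only a limit of the assay: in this assay compound 1 gives > 50000 nM. Compound 2 `Oc1cccc(-c2cc(-c3ccoc3)cc(-c3ccccc3O)n2)c1` yields a limit as well; in this assay compound 2 gives > 50000 nM. Both readings sit at the limit of > 50000 nM in this assay, at which 2 of the 2 values shown sit, so neither is a number that can be compared with the other. Compound 3 `Oc1ccc(-c2cc(-c3ccoc3)cc(-c3ccccc3O)n2)cc1` has not yet been measured. It differs from compound 2 by 4-hydroxyphenyl in place of 3-hydroxyphenyl on an aromatic carbon. For the measured compounds named here, no step between measured compounds is available; compound 1, which also carries a 4-hydroxyphenyl group, gives > 50000 nM, itself a limit. No change beyond the usual scatter is expected, so the expected step of a number no higher from compound 2 to compound 3 (the limit leaves the size open) is essentially flat. Compound 3 is expected to give about 50000 nM, with a range from 20000 nM to 200000 nM, and most likely to be reported again only as a limit.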

Compound 3, half-maximal inhibitory concentration: > 50000 nM
Compound 3: only a limit was reported; the forecaster's own chance of this, stated with the estimate: 85%; the middle value sits exactly at the limit.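

In this assay compound 3 gives > 50000 nM, again only a limit of the assay. No step to compound 3 from compound 2 or compound 1 can be read, because none of the three readings is an exact number: the limit of > 50000 nM in this assay, at which 3 of the 3 values shown sit.

Whether either group swap changes the true value of these compounds stays open.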